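Swapping a side chain on an oxime core

This account rests on a few compounds, and the source may have more. Where it says the series, first, only, none or still open, it means among the compounds named here.

Compound 1 `COCCOCn1cc[n+](C)c1/C=N/O`: -2.81
Compound 2 `C[n+]1ccn(COCCC[Si](C)(C)C)c1/C=N/O`: 0.43
Compound 3 `C[n+]1ccn(COCC(C)(C)CBr)c1/C=N/O`: -0.81

In a physicochemical assay for lipophilicity (on this read-out lower numbers stand for lower lipophilicity and higher numbers for higher lipophilicity), compound 1 stands lowest of the three measured compounds. Its nearest neighbour is compound 3, with a number 2.00 log units higher from compound 1 to compound 3 (beyond the scatter), and furthest away is compound 2, with a number 3.24 log units higher from compound 1 to compound 2 (beyond the scatter). Between the other two, a number 1.24 log units lower from compound 2 to compound 3 (beyond the scatter).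

Compound 4 `CN(C)CCn1cc[n+](C)c1/C=N/O` is not yet measured. It differs from compound 1 in one place: (dimethylamino)methyl in place of 2-methoxyethoxy on a saturated chain carbon bound to an aromatic nitrogen. The two steps that start from compound 1 both replace a group containing oxygen with a group built mostly of carbon, and both raise this assay by a large amount. The change to compound 4 also removes a group with two oxygens, but the entering group is smaller and brings a nitrogen, so the measured steps only partly bear on it. For compound 4 the expected step is a number 0.61 log units higher from compound 1 to compound 4 (beyond the scatter), which is estimated to be a rise beyond the scatter, though a smaller one than either step that starts from compound 1. For compound 4 the estimate in this assay is -2.2, in the range -3.2 to -1.2.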

Compound 4, distribution coefficient: -3.06
Estimate against measurement, compound 4: 0.86 log units above, and the stated range covers the measured number.
By their numbers in this assay, from the lowest: compounds 4 and 1 (each within the scatter of the next); then compound 3; then compound 2.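

In this assay the exchange of 2-methoxyethoxy for (dimethylamino)methyl on a saturated chain carbon bound to an aromatic nitrogen gives a number 0.25 log units lower from compound 1 to compound 4 (within the scatter) and so leaves compound 4 and compound 1 indistinguishable on this read-out. The earlier steps shown here from compound 1 were both large, so compound 4 shows that replacing this side chain does not always move the number, and it stands as the exception among the three steps from compound 1. No supporting data are available to explain this result.

On these data alone, compound 4 changes the chain's size and its heteroatoms at once, so the contribution of each remains open. As far as these compounds go, it is also open whether a carboxylic acid or a longer chain ending in an amine would stay equally close to compound 1.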